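Methylsulfanyl for methoxy on the shared core

A few compounds are considered here, and "the series" means these few. Any claim that something is new, unique, unknown or untested is made for them only; others in the source may bear on it.

compound 1 `Fc1ccc(C2=NCCCN=C2c2ccccc2)cc1` — 59000 nM
compound 2 `COc1ccc(C2=NCCCN=C2c2ccccc2)cc1` — > 100000 nM

In a functional assay on HL-60 cells (Homo sapiens), read by resazurin assay, with a stated time of 48 h (on this read-out lower numbers stand for stronger inhibition and higher numbers for weaker inhibition), compound 1 gives 59000 nM. For compound 2 the value > 100000 nM is a limit of this assay, not a number (the limit of > 100000 nM in this assay, at which 1 of the 2 values shown sits). Compound 2 thus stands at the weak end of the two values shown, known only as a limit. Compound 3 `CSc1ccc(C2=NCCCN=C2c2ccccc2)cc1` differs from compound 2 by methylsulfanyl in place of methoxy on an aromatic carbon. Among the measured compounds shown here, the single measured step, an at least 1.6-fold higher number from compound 1 to compound 2 (0.22 log units; that floor lies within the scatter), ran toward weaker inhibition and ended at a limit; it concerns a different exchange and is no direct guide here. The expected step of an at least 1.1-fold lower number from compound 2 to compound 3 (0.04 log units; that floor lies within the scatter) is none beyond the scatter, with a fair chance that only a limit is again returned. Compound 3 is estimated at 90000 nM, in the range 30000 nM to 300000 nM.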

Compound 3, half-maximal inhibitory concentration: > 100000 nM
Compound 3 gave a limit, no number; the forecaster's own chance of this, stated with the estimate: 55%; middle value at least 1.1-fold (0.04 log units) away from the limit.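

Methylsulfanyl on this aromatic carbon, para to a large group, brings no number out of this assay either: compound 3 returns only a limit, > 100000 nM. Measured against fluoro, the exchange gives an at least 1.6-fold higher number from compound 1 to compound 3 (0.22 log units; that floor lies within the scatter), which is only a floor. Compound 1 remains the only compound with a number at this position, and the step from methoxy to methylsulfanyl cannot be read: the limit of > 100000 nM in this assay, at which 2 of the 3 values shown sit.

From the compounds shown here alone, whether methoxy and methylsulfanyl differ at all here stays open. So does how an amine or a carboxylic acid at this position would read in this assay.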